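Dimethylcarbamoyl in Place of 1-methyl-1H-pyrazol-4-yl

The source may report more compounds than this note shows. Statements on the series, on what has been measured and on what is new or still open speak of the compounds shown alone.

Measured so far, each value being a limit of a functional assay on CHO cells for agonist activity at sphingosine 1-phosphate receptor 2 (Homo sapiens), read by fluorescence and calcium flux, with a stated time of 3 min; on this read-out higher numbers stand for weaker inhibition and lower numbers for stronger inhibition:
compound 1 `Cc1cc(NNC(=O)Nc2cc(Cl)nc(Cl)c2)ncc1C#N`, > 23000 nM;
compound 2 `Cc1cc(C#N)nc(NNC(=O)Nc2cc(Cl)nc(Cl)c2)c1`, > 23000 nM;
compound 3 `Cc1cc(NNC(=O)Nc2cc(Cl)nc(Cl)c2)nc(-c2cnn(C)c2)c1`, > 23000 nM.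

Compound 3 stands at a limit, not a number, in this assay: its value is > 23000 nM. The same holds for the two others, as the limit of > 23000 nM in this assay, at which 3 of the 3 values shown sit, shows. Within the data shown here, the only single-place step, a step that the two limits leave unreadable from compound 2 to compound 3, is left unreadable by the two limits.

Compound 4 `Cc1cc(NNC(=O)Nc2cc(Cl)nc(Cl)c2)nc(C(=O)N(C)C)c1` differs from compound 3 by dimethylcarbamoyl in place of 1-methyl-1H-pyrazol-4-yl on an aromatic carbon. Among the measured compounds shown here, no measured step bears on this change, and no step among the three compounds is readable. For compound 4 a step that the limit leaves unreadable from compound 3 to compound 4 is therefore expected, most likely again reaching only the limit. Compound 4 is estimated at 30000 nM, within 8000 nM to 100000 nM.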

Compound 4, half-maximal inhibitory concentration: > 23000 nM
Compound 4: only a limit was reported; the forecaster's own chance of this, stated with the estimate: 80%; the middle value does not contradict the limit.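

In this assay, among these compounds, compound 4 gives > 23000 nM, which is a limit, so no step from compound 2 or compound 3 to compound 4 can be read. The compounds shown leave open whether any of these groups changes the read-out at all, as all sit at one value: the limit of > 23000 nM in this assay, at which 4 of the 4 values shown sit.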